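Amide Variation on a Shared Core

The source may hold more compounds than are shown below. What is called first, only, known or untested is meant among the compounds shown, and "the series" means these compounds.

Measured compounds:
compound 1 `CC(=O)Nc1c(C(O)(C(F)(F)F)C(F)(F)F)ccc2ccccc12`: 18 nM
compound 2 `O=C(CC1CCCC1)Nc1c(C(O)(C(F)(F)F)C(F)(F)F)ccc2ccccc12`: 81 nM
compound 3 `O=C(Nc1c(C(O)(C(F)(F)F)C(F)(F)F)ccc2ccccc12)c1cccc(C(F)(F)F)c1`: 84 nM

In an assay on LtK cells with ATP-sensitive inward rectifier potassium channel 11 (Homo sapiens) as the target (on this read-out lower numbers stand for an effect already at smaller amounts and higher numbers for an effect only at larger amounts of compound), compound 1 gives 18 nM, compound 2 gives 81 nM and compound 3 gives 84 nM. Compound 3 carries the highest number of the three, yet its gap to compound 2, a 1.0-fold higher number from compound 2 to compound 3 (0.02 log units; within the scatter), is within the scatter, so the two cannot be ordered; only its gap to compound 1, a 4.7-fold higher number from compound 1 to compound 3 (0.67 log units; beyond the scatter), lies beyond it. Compound 4 `O=C(Nc1c(C(O)(C(F)(F)F)C(F)(F)F)ccc2ccccc12)c1ccc(F)cc1` differs from compound 3 by 4-fluorophenyl in place of 3-(trifluoromethyl)phenyl on a carbonyl carbon. Among the measured compounds shown here, no measured step exchanges one aromatic group for another on that carbonyl carbon. The steps that come closest are a 4.7-fold higher number from compound 1 to compound 3 (0.67 log units; beyond the scatter) and a 4.5-fold higher number from compound 1 to compound 2 (0.65 log units; beyond the scatter), both of which replace the methyl of compound 1 with a larger group, and a 1.0-fold higher number from compound 2 to compound 3 (0.02 log units; within the scatter), which swaps two larger groups without a change beyond the scatter. The swap between two substituted phenyl groups in compound 4 is therefore expected to give a 1.2-fold lower number from compound 3 to compound 4 (0.08 log units; within the scatter), no step beyond the scatter. Compound 4 is estimated at 70 nM, between 25 nM and 200 nM.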

Compound 4, half-maximal effective concentration: 70 nM
For compound 4 middle estimate and measured number coincide at the digits printed; measured number inside the range.
By their numbers in this assay, from the lowest: compound 1; then compounds 4, 2 and 3 (each within the scatter of the next).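

In this assay, among the compounds shown here, the first exchange of one substituted phenyl group for another on this carbonyl carbon, 4-fluorophenyl for 3-(trifluoromethyl)phenyl, gives a 1.2-fold lower number from compound 3 to compound 4 (0.08 log units; within the scatter) and so leaves the number unchanged within the scatter, even though the entering group has fewer heavy atoms and a different substituent. The exchange of cyclopentylmethyl for 4-fluorophenyl gives a 1.2-fold lower number from compound 2 to compound 4 (0.06 log units; within the scatter) in the same way, so compounds 2, 3 and 4 cannot be ordered, while the methyl amide stays apart, with a 3.9-fold higher number from compound 1 to compound 4 (0.59 log units; beyond the scatter) as the step. No measurement offered here accounts for this result. The compounds shown leave open whether an ethyl group on this carbonyl carbon would stay close to compound 1 or join the other three. They also leave open how this position would respond to a chain ending in an amine or a carboxylic acid.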